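The source may report more compounds than this note shows. Statements on the series, on what has been measured and on what is new or still open speak of the compounds shown alone.

Compound 1 `O=C1COc2ccc(-c3cnc(Cl)c(NS(=O)(=O)c4ccc(F)cc4)c3)cc2N1c1ccc(F)cc1` is recorded in a functional assay on HeLa cells (Homo sapiens) for antiproliferative activity, read by MTT assay, with a stated time of 72 h (on this read-out higher numbers stand for weaker inhibition and lower numbers for stronger inhibition), at a limit of the assay, > 40000 nM. Compound 2 `COc1ncc(-c2ccc3c(c2)N(c2ccc(F)cc2)C(=O)CO3)cc1NS(=O)(=O)c1ccc(F)cc1` gives 10500 nM. Compound 3 `O=C1COc2ccc(-c3cccc(NS(=O)(=O)c4ccc(F)cc4)c3)cc2N1c1ccc(F)cc1` likewise sits at a limit, > 40000 nM.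

Within the data shown here, compound 2 thus stands as the only outright number among the three; the other two values are limits (the limit of > 40000 nM in this assay, at which 2 of the 3 values shown sit). Among the measured compounds shown here, the one measured step, an at least 3.8-fold lower number from compound 1 to compound 2 (0.58 log units; beyond the scatter), concerns the group on the aromatic carbon and not the amide-type nitrogen. Compound 4 `COc1cccc(N2C(=O)COc3ccc(-c4cnc(OC)c(NS(=O)(=O)c5ccc(F)cc5)c4)cc32)c1` differs from compound 2 by 3-methoxyphenyl in place of 4-fluorophenyl on an amide-type nitrogen in a ring. For the measured compounds named here, no measured step touches this place, so no shift beyond the usual scatter is expected, a 1.1-fold lower number from compound 2 to compound 4 (0.02 log units; within the scatter). Compound 4 is therefore estimated at 10000 nM, within a range from 3500 nM to 30000 nM.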

Compound 4, half-maximal inhibitory concentration: > 40000 nM
Compound 4 gave a limit, no number; the forecaster's own chance of this, stated with the estimate: 20%; middle value at least 4.0-fold (0.60 log units) away from the limit.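

Among these compounds, the group on the amide-type nitrogen in a ring, which no earlier step touched, does matter in this assay: 3-methoxyphenyl in place of 4-fluorophenyl gives an at least 3.8-fold higher number from compound 2 to compound 4 (0.58 log units; beyond the scatter). Compound 4 gives > 40000 nM, which is a limit and not a number. The true size of this step therefore stays unknown, as compound 4 joins compound 1 and compound 3 at the same limit: the limit of > 40000 nM in this assay, at which 3 of the 4 values shown sit.

On these data alone, it remains open whether another group on this nitrogen, such as 4-methoxyphenyl, a pyridyl ring or a plain methyl, would keep the value of compound 2 or lower it.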